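Where compound 3 may land on distribution

The compounds below may be only part of what the source reports. "The series", "measured", "known", "first", "only" and "open" are said of these compounds alone.

Of the compounds shown here, two with a shared core have been measured in an in vivo ADME assay on the whole organism for pharmacokinetics, with Canis familiaris (Canis lupus familiaris) as the target; a higher number here means that more of the compound sits outside the plasma, a lower number that more of the compound stays in the plasma. Compound 1 `O=C(Nc1cccnc1-c1ccsc1)N1CCN2C(=O)N([C@H]3C[C@@H]3c3ccccc3)C(=O)[C@@H]2C1` gives 1 L/kg, the higher of the two numbers. Compound 2 `CS(=O)(=O)c1cc(Cl)c(NC(=O)N2CCN3C(=O)N([C@H]4C[C@@H]4c4ccccc4)C(=O)[C@@H]3C2)c(Cl)c1` gives 0.3 L/kg, and the gap between them lies beyond the usual scatter of repeated measurements.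

Compound 3 `O=C(Nc1cccc(Cl)c1Cl)N1CCN2C(=O)N([C@H]3C[C@@H]3c3ccccc3)C(=O)[C@@H]2C1` has not been measured yet. It keeps the core of compound 1 and changes one group on an amide-type nitrogen, with 2,3-dichlorophenyl in place of 2-(thiophen-3-yl)pyridin-3-yl (2,3-dichlorophenyl in place of 2-(thiophen-3-yl)pyridin-3-yl on an amide-type nitrogen). Among the compounds with values here, no measured pair shows what a single change of this kind does, so any expectation here is loose. Compound 2 at 0.3 L/kg shows that a compound on this core can sit well under compound 1, so the expectation leans slightly downward. In this assay the expected change is small, a 1.3-fold lower number from compound 1 to compound 3 (0.10 log units; within the scatter), and it probably stays within the scatter. For compound 3 the estimated value is 0.8 L/kg, with an expected range of 0.4 L/kg to 1.6 L/kg.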

Compound 3, volume of distribution at steady state: 2.5 L/kg
The estimate for compound 3 lay 3.1-fold (0.49 log units) below the measured number; measured number outside the range, above it.
By their numbers in this assay, from the lowest: compound 2; then compound 1; then compound 3.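

In this assay, within the data shown here, the step with 2,3-dichlorophenyl in place of 2-(thiophen-3-yl)pyridin-3-yl on an amide-type nitrogen gives a 2.5-fold higher number from compound 1 to compound 3 (0.40 log units; beyond the scatter) and is the first single-place comparison on the shared core. It shows that the group on this nitrogen can, on its own, move the number by more than ordinary repeat scatter, and that this change moves it upward, towards more of the compound sitting outside the plasma. Among these compounds, nothing measured so far explains the rise, so the step records what happened but not the reason for it.

Because the swap removes both aromatic rings of the old group and brings in a chlorinated carbon ring with no hydrogen-bond acceptors, this single step cannot show which part of the change matters. On these data alone, a plain phenyl, a 2-chlorophenyl or a phenyl carrying an amine or a carboxylic acid in this place would help to separate those parts, and how the number would respond to any of them remains open.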